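Cytotoxicity of benzothiazolyl benzamides: carboxymethoxy analogue

The source may hold more compounds than are shown below. What is called first, only, known or untested is meant among the compounds shown, and "the series" means these compounds.

Measured so far:
compound 1 `COc1cc(Cl)c(C(=O)Nc2cccc(-c3nc4ccccc4s3)c2)cc1[N+](=O)[O-]` — > 25000 nM
compound 2 `COc1ccc(NC(=O)c2cc([N+](=O)[O-])ccc2Cl)cc1-c1nc2ccccc2s1` — > 25000 nM

Both values come from an ADME assay on HEK293 cells (Homo sapiens) for cytotoxicity, with a stated time of 72 h; a higher number here means that more compound is needed for the effect, a lower number that less compound is needed. For compound 1 the value > 25000 nM is a limit of the assay, not a number. For compound 2 the value > 25000 nM is likewise a limit. Compound 1 therefore stands at the limit of > 25000 nM in this assay, at which 2 of the 2 values shown sit, and nothing distinguishes it from compound 2 on these figures. Going by the values given here, no step between measured compounds that differ in one place exists in this set.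

Compound 3 `O=C(O)COc1cc(Cl)c(C(=O)Nc2cccc(-c3nc4ccccc4s3)c2)cc1[N+](=O)[O-]` is the next compound for this assay. It differs from compound 1 as follows: carboxy in place of hydrogen on a saturated chain carbon bound to an oxygen on an aromatic ring

With only limits on hand, no direction can be read from the measured compounds, and no step beyond the scatter is expected in this assay. Compound 3 is therefore expected to sit at or near the same limit, with an estimate of 30000 nM (range 15000 nM to 80000 nM); the implied step that the limit leaves unreadable from compound 1 to compound 3 is expected to be none beyond the scatter.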

Compound 3, half-maximal effective concentration: > 25000 nM
Compound 3: only a limit was reported; the forecaster's own chance of this, stated with the estimate: 85%; the middle value is on the limit's open side.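

No step can be read between compound 1 and compound 3 in this assay; both values are limits of the assay, not numbers. The compounds shown leave open whether any change in this series gives a measurable value, since all remain at one limit: the limit of > 25000 nM in this assay, at which 3 of the 3 values shown sit.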